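The source may hold more compounds than are shown below. What is called first, only, known or untested is meant among the compounds shown, and "the series" means these compounds.

Measured so far:
- compound 1 `CCCN(C)C(=O)COC(=O)/C=C/c1ccc(NC(=O)C2(NC(=O)c3ccc4c(C5CCCC5)c(-c5ncc(Cl)cn5)n(C)c4c3)CCC2)cc1OCC` — < 200000 ug/mL
- compound 2 `CCOc1cc(NC(=O)C2(NC(=O)c3ccc4c(C5CCCC5)c(-c5ncc(Cl)cn5)n(C)c4c3)CCC2)ccc1/C=C/C(=O)OCC(=O)N(C)C(C)C` — < 200000 ug/mL

Compound 1 is `CCCN(C)C(=O)COC(=O)/C=C/c1ccc(NC(=O)C2(NC(=O)c3ccc4c(C5CCCC5)c(-c5ncc(Cl)cn5)n(C)c4c3)CCC2)cc1OCC`. In an ADME assay for solubility (a higher number here means a more soluble compound, a lower number a less soluble compound), compound 1 gives < 200000 ug/mL, which is a limit of the assay and not a number. Compound 2 is `CCOc1cc(NC(=O)C2(NC(=O)c3ccc4c(C5CCCC5)c(-c5ncc(Cl)cn5)n(C)c4c3)CCC2)ccc1/C=C/C(=O)OCC(=O)N(C)C(C)C`. In this assay compound 2 gives < 200000 ug/mL, again a limit of the assay. Among the measured compounds shown here, the one measured step, a step that the two limits leave unreadable from compound 1 to compound 2, cannot be read because both ends sit at a limit, as the limit of < 200000 ug/mL in this assay, at which 2 of the 2 values shown sit, records. Compound 2 therefore stands only as a limit, with nothing in the numbers to place it higher or lower than compound 1.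

Compound 3 is `CCOc1cc(NC(=O)C2(NC(=O)c3ccc4c(C5CCCC5)c(-c5ncc(Cl)cn5)n(C)c4c3)CCC2)ccc1/C=C/C(=O)OCC(=O)N1CCCC1`. It differs from compound 2 by pyrrolidin-1-yl in place of isopropyl(methyl)amino on a carbonyl carbon. For the measured compounds named here, the only measured step, a step that the two limits leave unreadable from compound 1 to compound 2, also changes the group on that amide nitrogen and gives no readable size, so no direction beyond the scatter can be claimed. For compound 3 the step is expected to be a step that the limit leaves unreadable from compound 2 to compound 3, and compound 3 is expected to return the same limit. Compound 3 is estimated at 120000 ug/mL, within 30000 ug/mL to 200000 ug/mL.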

Compound 3, solubility: < 200000 ug/mL
Compound 3: no number, only a limit; the forecaster's own chance of this, stated with the estimate: 85%; the middle value is on the limit's open side.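

Among the compounds shown here, no step among compound 1, compound 2 and compound 3 can be read in this assay because all three values are one limit of the assay, not numbers: the limit of < 200000 ug/mL in this assay, at which 3 of the 3 values shown sit.

From the compounds shown here alone, whether pyrrolidin-1-yl, isopropyl(methyl)amino and methyl(propyl)amino on a carbonyl carbon differ at all in this assay remains open.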